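The source may report more compounds than this note shows. Statements on the series, on what has been measured and on what is new or still open speak of the compounds shown alone.

In an ADME assay on microsomes from liver (Homo sapiens) for metabolic stability (on this read-out higher numbers stand for fast clearance and lower numbers for slow clearance), compound 3 `O=C(N1CCC(c2ccccc2)CC1)N(c1ncccc1Cl)[C@@H]1CCCNC1` stands at < 9.3 mL.min-1.g-1, which is a limit and not a number. Compound 1 `Cc1cccnc1N(C(=O)N1CCC(c2ccccc2F)CC1)[C@@H]1CCCNC1`, which carries the 3-methylpyridin-2-yl group, reads < 8 mL.min-1.g-1, also only a limit. Compound 2 `Cc1cnc2c(c1)nnn2-c1ccc(CCC(=O)N(c2ncccc2Cl)[C@@H]2CCCNC2)nc1` gives a true number, 9.3 mL.min-1.g-1. Compound 4 `Cc1cccnc1N(C(=O)N1CCC(c2ccccc2)CC1)[C@@H]1CCCNC1` is not yet measured. It departs from compound 3 by methyl in place of chloro on an aromatic carbon. Within the data shown here, no measured pair isolates this swap, so the expectation rests on the neighbouring compounds alone. The step expected a step that the limit leaves unreadable from compound 3 to compound 4 lies within the scatter, with no direction favoured. The estimated value for compound 4 is 9 mL.min-1.g-1, with an expected range of 6 mL.min-1.g-1 to 16 mL.min-1.g-1.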

Compound 4, intrinsic clearance in microsomes: < 8 mL.min-1.g-1
Compound 4: only a limit was reported; the forecaster's own chance of this, stated with the estimate: 55%; middle value at least 1.1-fold (0.05 log units) away from the limit.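

Compound 4 stands at < 8 mL.min-1.g-1, a limit. Among these compounds, compound 1 and compound 3 also give only limits, so no step to compound 4 can be read. From the compounds shown here alone, whether methyl in place of chloro, or hydrogen in place of fluoro, changes clearance remains open.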